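Lengthening the Butyl Chain at the Alkyne End of Compound 3

This account rests on a few compounds, and the source may have more. Where it says the series, first, only, none or still open, it means among the compounds named here.

Three compounds have so far been tested in a functional assay on MCF7 cells (Homo sapiens) for antiproliferative activity, read by MTT assay, with a stated time of 3 days; on this read-out higher numbers stand for weaker inhibition and lower numbers for stronger inhibition:
compound 1 `CCCCC#Cc1cn(C/C=C\CN2C(=O)c3ccccc3C2=O)c(=O)[nH]c1=O` gives 45000 nM;
compound 2 `CCCCC#Cc1cn(C/C=C/CN2C(=O)c3ccccc3C2=O)c(=O)[nH]c1=O` gives 8800 nM;
compound 3 `CCCCc1ccc(C#Cc2cn(C/C=C\CN3C(=O)c4ccccc4C3=O)c(=O)[nH]c2=O)cc1` gives 43000 nM.

Compound 3 stands second highest of these three numbers. Compound 1 lies within the usual scatter of it, while the step of a 5.1-fold lower number from compound 1 to compound 2 (0.71 log units; beyond the scatter) rests on the two compounds differing only in the drawn configuration of the double bond (the fact that compounds 1 and 2 differ only in the configuration as drawn). Compound 4 `CCCCCc1ccc(C#Cc2cn(C/C=C\CN3C(=O)c4ccccc4C3=O)c(=O)[nH]c2=O)cc1` carries the change (methyl in place of hydrogen on a saturated chain carbon, four bonds along the chain from an aromatic carbon). Among the compounds with values here, the only measured step at that end of the molecule, a 1.0-fold lower number from compound 1 to compound 3 (0.02 log units; within the scatter), exchanged the whole butyl for 4-butylphenyl without leaving the scatter, so methyl in place of hydrogen on the chain is expected to give no step beyond the scatter: a 1.1-fold lower number from compound 3 to compound 4 (0.03 log units; within the scatter). Compound 4 is therefore estimated at 40000 nM, between 15000 nM and 100000 nM.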

Compound 4, half-maximal inhibitory concentration: > 100000 nM
Compound 4 ended at the assay's limit; the forecaster's own chance of this, stated with the estimate: 10%; middle value at least 2.5-fold (0.39 log units) away from the limit.
By their numbers in this assay, from the lowest: compound 2; then compounds 3 and 1 (each within the scatter of the next). At a limit, above all of these: compound 4.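

Compound 4 carries a limit of the assay, not a number: the limit of > 100000 nM in this assay, at which 1 of the 4 values shown sits. Even so, one added methyl on the chain is enough to show as an at least 2.3-fold higher number from compound 3 to compound 4 (0.36 log units; beyond the scatter), whereas exchanging butyl for 4-butylphenyl stayed within the scatter. Against the plain butyl, 4-pentylphenyl gives an at least 2.2-fold higher number from compound 1 to compound 4 (0.34 log units; beyond the scatter), so this end of the molecule does respond to the length of the chain.

Going by these compounds, the true size of both steps remains unknown. Also open, on these data alone, is how a propyl or hexyl chain in place of the pentyl would read, and whether the same methyl would matter with the double bond drawn E.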